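Swapping a Hydroxyl Group for Diethylamine on the Chain

The compounds below may be only part of what the source reports. "The series", "measured", "known", "first", "only" and "open" are said of these compounds alone.

Of the compounds shown here, three built on one shared core have been measured in an assay on HEK293 cells for agonist activity at Toll-like receptor 8 (Homo sapiens), read by spectrophotometry; a higher number here means that more compound is needed for the effect, a lower number that less compound is needed. Compound 1 `CCCCNc1nc(N)nc(C)c1CCCN1Cc2ccccc2C1` gives 29 nM, compound 2 `CCCCNc1nc(N)nc(C)c1C#CCN1CCCCC1` gives 3790 nM, and compound 3 `CCCCNc1nc(N)nc(C)c1CCCC(C)(C)O` gives 1220 nM. Compound 3 thus stands second highest of the three: compound 2 sits higher, beyond the scatter, while compound 1 sits far lower, also beyond the scatter. Compound 4 `CCCCNc1nc(N)nc(C)c1CCCN(CC)CC` has not yet been measured. It differs from compound 3 in one place: diethylamino in place of 1-hydroxy-1-methylethyl on a saturated chain carbon, three bonds along the chain from an aromatic carbon. Because compound 1 gives 29 nM and its saturated chain also ends at a nitrogen, the step of an 8.1-fold lower number from compound 3 to compound 4 (0.91 log units; beyond the scatter) is expected to be a clear fall, beyond the scatter. Compound 4 is estimated at 150 nM, within 30 nM to 800 nM.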

Compound 4, half-maximal effective concentration: 254 nM
Compound 4: middle estimate off by 1.7-fold (0.23 log units), on the low side; low and high end bracket the measured number.
By their numbers in this assay, from the lowest: compound 1; then compound 4; then compound 3; then compound 2.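

Among these compounds, replacing 1-hydroxy-1-methylethyl with diethylamino gives a 4.8-fold lower number from compound 3 to compound 4 (0.68 log units; beyond the scatter) in this assay, the first single-place comparison in this set. It shows that the group on a saturated chain carbon, three bonds along the chain from an aromatic carbon, affects this number. The change removes the hydrogen-bond donor and puts nitrogen in place of oxygen, but no measurement here explains the step. The compounds shown cannot separate the loss of the hydroxyl from the gain of the amine. From the compounds shown here alone, a primary amine or a longer chain at this place remains open.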